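This account rests on a few compounds, and the source may have more. Where it says the series, first, only, none or still open, it means among the compounds named here.

Measured so far in a functional assay on the whole organism (strain albino) for inhibition, with Rattus norvegicus as the target, read by paw edema, with stated times of 1 h and 2 h, at a dose of 200 mg/kg by the oral route; a higher number here means more inhibition at the dose given (going by the name of the read-out), a lower number less inhibition:
- compound 1, `O=c1oc2ccccc2cc1C1=NN(c2ccccc2)[C@@H](c2ccccc2)C1`: 27.2%
- compound 2, `O=c1oc2ccccc2cc1C1=NN(c2ccccc2)[C@@H](/C=C/c2ccccc2)C1`: 26.7%
- compound 3, `O=c1oc2ccccc2cc1C1=NN(c2ccccc2)[C@@H](c2ccc(Cl)cc2)C1`: 39.2%

Compound 1 stands second highest of the three numbers. Its nearest neighbour is compound 2, a number 0.5 percentage points lower from compound 1 to compound 2 (within the scatter); the furthest is compound 3, a number 12 percentage points higher from compound 1 to compound 3 (beyond the scatter).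

Compound 4, `O=c1oc2ccccc2cc1C1=NN(c2ccccc2)[C@@H](c2ccc(Cl)cc2Cl)C1`, differs from compound 1 by 2,4-dichlorophenyl in place of phenyl on a saturated ring carbon.

The step that bears on this is the one with a single chloro in place of hydrogen, a number 12 percentage points higher from compound 1 to compound 3 (beyond the scatter), a modest rise beyond the scatter. The step from compound 2 to compound 3 is the same size, a number 12.5 percentage points higher from compound 2 to compound 3 (beyond the scatter). Among the compounds with values here, a second chlorine on the same ring has no measured precedent, so an upward step of about the same size is expected, a number 13.8 percentage points higher from compound 1 to compound 4 (beyond the scatter), rather than a larger one. Compound 4 is therefore estimated at 41%, between 30% and 52%.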

Compound 4, a percentage reported as inhibition, in the whole organism at one dose (the size of the read-out at that dose, not a potency): 56.7%
Compound 4: middle estimate off by 15.7 percentage points, on the low side; the whole stated range lies below it.
By their numbers in this assay, from the lowest: compounds 2 and 1 (each within the scatter of the next); then compound 3; then compound 4.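

A second chloro on the aryl group at this saturated ring carbon still gives a rise beyond the scatter, a number 17.5 percentage points higher from compound 3 to compound 4 (beyond the scatter), so the gain does not end with the single chloro. Replacing the whole group gives a number 29.5 percentage points higher from compound 1 to compound 4 (beyond the scatter), and against the 2-phenylethenyl group the result is a number 30 percentage points higher from compound 2 to compound 4 (beyond the scatter). No measurement shown here explains this rise.

Still open, going by these compounds, is whether other substituents on this ring, such as fluoro, bromo or methoxy, would match the two chloro atoms. Also open, on these data alone, is whether an amine on the ring would keep the inhibition.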